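Adding an amino link to compound 2

The compounds below may be only part of what the source reports. "The series", "measured", "known", "first", "only" and "open" are said of these compounds alone.

Among the compounds with values here, in a functional assay on MDA-MB-231 cells (Homo sapiens) for inhibition, read by MTT assay, with a stated time of 72 h (on this read-out higher numbers stand for weaker inhibition and lower numbers for stronger inhibition), compound 2 `COC(=O)c1ccc(-n2cc(CCCNC(=S)c3ccc(C)cc3)nn2)cc1` gives 82400 nM, the only true number so far. Compound 1 `COC(=O)c1ccc(-n2cc(CCCNC(=O)c3ccc(C)cc3)nn2)cc1` reaches only a limit, > 100000 nM. Compound 3 `COC(=O)c1ccc(-n2cc(CCCOC(=O)c3ccc(C)cc3)nn2)cc1` also reaches only a limit, > 100000 nM.

Compound 4 `COC(=O)c1ccc(-n2cc(CCCNC(=S)Nc3ccc(C)cc3)nn2)cc1` has (4-methylphenyl)amino in place of 4-methylphenyl on a thiocarbonyl carbon. Within the data shown here, the one measured step nearby, an at least 1.2-fold lower number from compound 1 to compound 2 (0.08 log units; that floor lies within the scatter), changes a carbonyl to a thiocarbonyl, not this group, and stays within the scatter. That step is only a floor, set by the limit of > 100000 nM in this assay, at which 2 of the 3 values shown sit. Among the measured compounds shown here, no measured step therefore points to a large change, and the expected step, a 1.4-fold lower number from compound 2 to compound 4 (0.14 log units; within the scatter), is none beyond the scatter. For compound 4 the estimated value is 60000 nM, with an expected range from 20000 nM to 100000 nM.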

Compound 4, half-maximal inhibitory concentration: > 100000 nM
Compound 4: a limit, no number (the forecaster's own chance of this, stated with the estimate: 30%); middle value at least 1.6-fold (0.22 log units) from the limit.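

On the thiocarbonyl carbon, (4-methylphenyl)amino in place of 4-methylphenyl gives an at least 1.2-fold higher number from compound 2 to compound 4 (0.08 log units; that floor lies within the scatter), so in this assay the added amino link brings no visible gain. The value of compound 4 is a limit, not a number. The true size of this step stays hidden because the read-out ends there: the limit of > 100000 nM in this assay, at which 3 of the 4 values shown sit.

Within the data shown here, compound 2 thus still holds the only true number. As far as these compounds go, whether a longer chain, or a carboxylic acid on the shared core, would give further true numbers remains open.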